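This account rests on a few compounds, and the source may have more. Where it says the series, first, only, none or still open, it means among the compounds named here.

Measured compounds:
Compound 1 `COc1ccc(S(=O)(=O)Nc2ccc(-c3nc4ccccc4o3)cc2)cc1` — in an assay on isolated protein for inhibition of malate dehydrogenase, mitochondrial (Sus scrofa), with stated times of 45 min and 30 min (on this read-out higher numbers stand for weaker inhibition and lower numbers for stronger inhibition), compound 1 gives only the limit > 63000 nM.
Compound 2 `Cc1ccccc1S(=O)(=O)Nc1ccc2oc(-c3ccccc3)nc2c1` — in this assay compound 2 gives only the limit > 63000 nM.
Compound 3 `O=S(=O)(Nc1ccc2oc(-c3ccccc3)nc2c1)c1ccccc1C(F)(F)F` — in this assay compound 3 gives only the limit > 63000 nM.

Compound 1 therefore stands at the limit, as every value shown does (the limit of > 63000 nM in this assay, at which 3 of the 3 values shown sit). Among the compounds with values here, the only step between measured compounds, a step that the two limits leave unreadable from compound 2 to compound 3, sits between two limits and cannot be sized. Compound 4 `Cc1ccccc1S(=O)(=O)Nc1ccc(-c2nc3ccccc3o2)cc1` differs from compound 1 by 2-methylphenyl in place of 4-methoxyphenyl on a sulfonyl sulfur. Within the data shown here, no measured step covers this change, and the three limits give no direction to read from. Compound 4 is expected to return a limit again, so the estimated step that the limit leaves unreadable from compound 1 to compound 4 is none beyond the scatter. The expected value for compound 4 in this assay is 100000 nM, between 50000 nM and 300000 nM.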

Compound 4, half-maximal inhibitory concentration: > 63000 nM
Compound 4: no number, only a limit (the forecaster's own chance of this, stated with the estimate: 85%); the middle value is on the limit's open side.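

No step can be read between compound 1 and compound 4, since both values are limits and not numbers: the limit of > 63000 nM in this assay, at which 4 of the 4 values shown sit. The compounds shown leave open which change, if any, would give a number in this assay rather than a limit.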